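The source may report more compounds than this note shows. Statements on the series, on what has been measured and on what is new or still open speak of the compounds shown alone.

Compound 1 `O=C1C(Nc2ccccc2)=CC(=O)c2c1nc1n2[C@H]2OC[C@@H](O)[C@H]2OC1`: > 8000 nM, a limit of the assay
Compound 2 `O=C1C(Nc2ccc(Br)cc2)=CC(=O)c2c1nc1n2[C@H]2OC[C@@H](O)[C@H]2OC1`: 5220 nM
Compound 3 `CCc1ccc(NC2=CC(=O)c3c(nc4n3[C@H]3OC[C@@H](O)[C@H]3OC4)C2=O)cc1`: 6510 nM

All three were tested in a functional assay on HeLa cells (Homo sapiens) for inhibition, read by sulforhodamine B assay; on this read-out higher numbers stand for weaker inhibition and lower numbers for stronger inhibition. Going by the values given here, compound 3 stands at 6510 nM, and the only other exact number gives a 1.2-fold higher number from compound 2 to compound 3 (0.10 log units; within the scatter).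

Compound 4 `Cc1ccc(NC2=CC(=O)c3c(nc4n3[C@H]3OC[C@@H](O)[C@H]3OC4)C2=O)cc1` is compound 3 with a shorter group: hydrogen in place of methyl on a saturated chain carbon bound to an aromatic carbon. This is hydrogen in place of methyl on a saturated chain carbon bound to an aromatic carbon, so that ethyl becomes methyl and 4-ethylphenyl becomes 4-methylphenyl.

Among the compounds with values here, no measured step makes this exact change. The closest evidence comes from changes on an aromatic carbon: ethyl in place of hydrogen gave an at least 1.2-fold lower number from compound 1 to compound 3 (0.08 log units; that floor lies within the scatter), bromo in place of hydrogen gave an at least 1.5-fold lower number from compound 1 to compound 2 (0.18 log units; that floor lies within the scatter), and ethyl in place of bromo gave the step already shown. With steps this small around compound 3, no step beyond the scatter is expected in this assay. The expected step is a 1.1-fold lower number from compound 3 to compound 4 (0.04 log units; within the scatter). Compound 4 is estimated at 6000 nM, with an expected range of 3500 nM to 10000 nM.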

Compound 4, half-maximal inhibitory concentration: 6590 nM
Compound 4: the middle estimate sits 1.1-fold (0.04 log units) below what was measured; measured number inside the range.
By their numbers in this assay, from the lowest: compounds 2, 3 and 4 (each within the scatter of the next). At a limit, above all of these: compound 1.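

In this assay, going by these compounds alone, shortening ethyl to methyl on this saturated chain carbon bound to an aromatic carbon gives a 1.0-fold higher number from compound 3 to compound 4 (0.01 log units; within the scatter), the first direct reading of a change within this group, and it shows that the chain length difference between 4-ethylphenyl and 4-methylphenyl does not register here. Methyl in place of bromo gives a 1.3-fold higher number from compound 2 to compound 4 (0.10 log units; within the scatter), so compounds 2, 3 and 4 cannot be ordered among themselves. Methyl in place of hydrogen gives an at least 1.2-fold lower number from compound 1 to compound 4 (0.08 log units; that floor lies within the scatter), and that figure is only a floor, set by the limit reached by compound 1: the limit of > 8000 nM in this assay, at which 1 of the 4 values shown sits.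

As far as these compounds go, whether a longer chain, an amine or a carboxylic acid at this place would move the number beyond the scatter stays open. From the compounds shown here alone, it is also open how far the step from compound 1 truly reaches.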